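The compounds below may be only part of what the source reports. "The series", "measured", "known", "first", "only" and "open" are said of these compounds alone.

Measured so far:
compound 1 `N/C(=N\NC(=S)N1CCCCCC1)c1ccccn1`: 89% in a functional assay on A-375 cells (Homo sapiens) for cytotoxicity, read by MTT assay, with a stated time of 72 h, tested at 100 uM; a lower number here means less inhibition of growth, a higher number more inhibition of growth at the concentration tested
compound 2 `N/C(=N\NC(=S)N1CCOCC1)c1ccccn1`: 14%
compound 3 `N/C(=N\NC(=S)N1CCOCC1)c1ccc(F)cn1`: 86.2%

Compound 2 and compound 3 share one core; the difference between the core of compound 1 and the core of compound 2 is not broken down here. From compound 2 to compound 3 the change is fluoro in place of hydrogen on an aromatic carbon, and it brought a number 72.2 percentage points higher from compound 2 to compound 3 (beyond the scatter). The same change, (fluoro in place of hydrogen on an aromatic carbon), leads from compound 1 to the not yet measured compound 4 `N/C(=N\NC(=S)N1CCCCCC1)c1ccc(F)cn1`; it occurs in two pairs among these compounds. Compound 1 already gives 89%, a number near the top of the scale, so there is little room for a rise like the earlier one. The step from compound 1 to compound 4 is expected to be small, a number 3 percentage points higher from compound 1 to compound 4 (within the scatter), because compound 1 already stands at 89%. For compound 4 the estimate is 92%, expected between 80% and 100%.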

Compound 4, percent growth inhibition at one concentration: 85.7%
Compound 4: the middle estimate sits 6.3 percentage points above what was measured; the measured number falls inside the stated range.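

In this assay, fluoro in place of hydrogen on an aromatic carbon gave a number 3.3 percentage points lower from compound 1 to compound 4 (within the scatter), so the large rise seen earlier did not repeat on the core of compound 1. The same change therefore did not carry over equally between the two cores: the same change on two cores in this assay, a number 72.2 percentage points higher (beyond the scatter) from compound 2 to compound 3 and a number 3.3 percentage points lower (within the scatter) from compound 1 to compound 4, 75.5 percentage points apart, beyond the scatter of two such steps. What this does not show is why: compound 1 already stands at 89%, near the top of the scale, and two pairs give no general rule.

The compounds shown leave open how a chloro, a methyl or an amine at this same place would behave on either core. They also leave open what fluoro would do on the other aromatic carbons of this ring.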